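The compounds below may be only part of what the source reports. "The series", "measured", "known", "first", "only" and "open" are said of these compounds alone.

Notes on the nitropyrimidine series in a functional assay on HepG2 cells (Homo sapiens) for antiproliferative activity, read by MTT assay, with a stated time of 48 h; a higher number here means a weaker inhibitor, a lower number a stronger inhibitor.

Compound 1 `CCOC(=O)CN(Cc1ccccc1)c1nc(NCc2ccccc2)ncc1[N+](=O)[O-]` and compound 2 `CCOC(=O)CN(Cc1ccccc1)c1nc(NCc2cccc(OC)c2)ncc1[N+](=O)[O-]` share one core; compound 3 `COC(=O)CN(C)c1nc(Nc2cccc(OC)c2)ncc1[N+](=O)[O-]` and compound 4 `COC(=O)CN(C)c1nc(Nc2ccccc2)ncc1[N+](=O)[O-]` share another, and the difference between the two cores is not broken down here. Compound 1 gives 21000 nM and compound 2 gives 33600 nM; the pair differs by hydrogen in place of methoxy on an aromatic carbon and the step is a 1.6-fold lower number from compound 2 to compound 1 (0.20 log units; within the scatter). Compound 3 gives 73400 nM, the highest number of the three measured. The same change, (hydrogen in place of methoxy on an aromatic carbon), leads from compound 3 to compound 4. Because the measured step of a 1.6-fold lower number from compound 2 to compound 1 (0.20 log units; within the scatter) sits within the scatter, the expected step of a 1.5-fold lower number from compound 3 to compound 4 (0.17 log units; within the scatter) is set small as well. Compound 4 is therefore estimated at 50000 nM, with a range of 20000 nM to 125000 nM.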

Compound 4, half-maximal inhibitory concentration: > 100000 nM
Compound 4: a limit, no number (the forecaster's own chance of this, stated with the estimate: 15%); middle value at least 2.0-fold (0.30 log units) from the limit.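

In this assay compound 4 gives > 100000 nM, which is a limit of the assay and not a number. Hydrogen in place of methoxy therefore gives only a floor on this core, an at least 1.3-fold higher number from compound 3 to compound 4 (0.13 log units; that floor lies within the scatter), and the comparison with the other core stays undecided: the same change on two cores in this assay, a 1.6-fold lower number (0.20 log units; within the scatter) from compound 2 to compound 1 and an at least 1.3-fold higher number (0.13 log units; that floor lies within the scatter) from compound 3 to compound 4; the limit leaves it open whether they differ The series thus shows neither that the change carries from one core to the other nor that it fails to, and the true size of the step on the core of compound 3 remains unknown.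

Still open, as far as these compounds go, is how an amine or a carboxylic acid in place of methoxy would read on either core. Also open, from the compounds shown here alone, is which single change separates the two cores.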